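Dropping the Methoxy Group from Compound 1

A few compounds are considered here, and "the series" means these few. Any claim that something is new, unique, unknown or untested is made for them only; others in the source may bear on it.

Measured compounds:
compound 1, `COc1ccc2[nH]cc(Cc3nn4c(-c5ccoc5C)nnc4s3)c2c1`: 30.8%
compound 2, `COc1ccc2[nH]c(C)c(Cc3nn4c(-c5ccoc5C)nnc4s3)c2c1`: 31.2%

In a functional assay on the whole organism (strain Wistar Albino) for inhibition, with Rattus norvegicus as the target, read by paw edema, with a stated time of 4 h, at a dose of 20 mg/kg (on this read-out lower numbers stand for less inhibition and higher numbers for more inhibition at the one dose given (going by the name of the read-out)), compound 1 gives 30.8%, while compound 2 gives 31.2%. Going by the values given here, the single step between them, a number 0.4 percentage points higher from compound 1 to compound 2 (within the scatter), lies within the scatter, so the numbers of compound 1 and compound 2 are level with each other.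

Compound 3 `Cc1occc1-c1nnc2sc(Cc3c[nH]c4ccccc34)nn12` differs from compound 1 by hydrogen in place of methoxy on an aromatic carbon. Among the compounds with values here, no measured step concerns the methoxy group; the only step on record, a number 0.4 percentage points higher from compound 1 to compound 2 (within the scatter), touches a different position and was itself within the scatter. The data therefore give no ground to expect a shift in either direction, and the step of a number 0.8 percentage points lower from compound 1 to compound 3 (within the scatter) is expected to stay within the scatter. Compound 3 is accordingly estimated at 30%, with a range from 18% to 42%.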

Compound 3, a percentage reported as inhibition, in the whole organism at one dose (the size of the read-out at that dose, not a potency): 30%
The estimate for compound 3 equals the measured number at the digits printed; low and high end bracket the measured number.
By their numbers in this assay, from the lowest: compounds 3, 1 and 2 (each within the scatter of the next).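

In this assay, going by these compounds alone, the step of a number 0.8 percentage points lower from compound 1 to compound 3 (within the scatter) is the first reading at this aromatic carbon, and it leaves the two compounds level with each other. Methoxy, with its two heavy atoms and one hydrogen-bond acceptor, can give way to hydrogen here without a difference that stands out from the scatter, so this read-out at the one dose shows no dependence on the methoxy group. Nothing at hand bears on why that is so.

The compounds shown leave open whether a carboxylic acid, an amine or a chlorine atom on this same aromatic carbon would give a number beyond the scatter. They also leave open whether compound 1 and compound 3 would stay level at other doses or at other times.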